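The compounds below may be only part of what the source reports. "The series", "measured", "known", "first", "only" and "open" are said of these compounds alone.

Measured compounds in the series:
compound 1 `Nc1ccccc1NC(=O)c1ccc(CSC(=S)N2CCN(C(c3ccccc3)c3ccccc3)CC2)cc1`, 8.7%
compound 2 `Nc1ccccc1NC(=O)c1ccc(CSC(=S)N2CCN(c3ccccc3)CC2)cc1`, 27.5%
compound 3 `CN(C(=S)SCc1ccc(C(=O)Nc2ccccc2N)cc1)c1cccnc1`, 26.5%

All three numbers come from a functional assay on A-375 cells (Homo sapiens) for antiproliferative activity, read by CCK-8 assay, with a stated time of 72 h, tested at 2 uM; on this read-out lower numbers stand for a weaker effect and higher numbers for a stronger effect at the one concentration tested. Compound 2 holds the highest of the three numbers. Compound 3 sits within the usual scatter of compound 2, so the two cannot be ordered against each other. Compound 1 lies beyond the scatter below compound 2, and this is the only gap in the set that counts as a real difference.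

Compound 4 `Nc1ccccc1NC(=O)c1ccc(CSC(=S)N2CCN(c3ccc(F)cc3)CC2)cc1` has not been measured. Its difference from compound 2 is fluoro in place of hydrogen on an aromatic carbon. The change is fluoro in place of hydrogen on an aromatic carbon, para to a large group, so that phenyl becomes 4-fluorophenyl. For the measured compounds named here, no pair of measured compounds carries this same change, so nothing in the set says what a fluoro on that ring does here. Given that, the expected step of a number 0.5 percentage points higher from compound 2 to compound 4 (within the scatter) is small and may fall in either direction, most likely none beyond the scatter. Compound 4 is therefore estimated at 28%, with a range from 12% to 45%.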

Compound 4, a percentage reported as inhibition, at one concentration (the size of the read-out at that concentration, not a potency): 20.9%
Beside the measured number, compound 4's estimate is 7.1 percentage points above it, and the stated range covers the measured number.
By their numbers in this assay, from the lowest: compound 1; then compounds 4, 3 and 2 (each within the scatter of the next).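

Phenyl to 4-fluorophenyl, with fluoro in place of hydrogen on an aromatic carbon para to a large group, is now read directly in this assay as a number 6.6 percentage points lower from compound 2 to compound 4 (within the scatter) and so cannot be told apart from no change at the one concentration tested. On this single pair, this position accepts a fluoro without a step beyond the scatter, which gives the series its first reading at this place and for this change. Nothing available explains the step or shows how much of it is real.

From the compounds shown here alone, it remains open whether a larger or differently built group at the same carbon, such as chloro, methoxy, an amine or a carboxylic acid, would give a step beyond the scatter in this assay or would also read like the hydrogen of compound 2. Also open, going by these compounds, is whether fluoro on another carbon of that ring would read the same, and whether compound 2 and compound 4 could be separated by a full concentration series rather than by a single concentration.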